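The compounds below may be only part of what the source reports. "The series", "measured", "known", "first", "only" and "open" are said of these compounds alone.

Two compounds of the series carry a measurement so far. Compound 1 `CCN(CC)c1nc(Nc2cccc([N+](=O)[O-])c2)nc(OC(C(F)(F)F)C(F)(F)F)n1` gives 200 nM in an assay on cells for activation of Cystic fibrosis transmembrane conductance regulator (Homo sapiens), read by fluorescence, with stated times of 10 min and 12 s; a lower number here means that less compound is needed, a higher number that more compound is needed for the effect. Compound 2 `CCN(CC)c1nc(Nc2cccc(Cl)c2)nc(OCC(F)(F)C(F)F)n1` gives 5400 nM in this assay, the highest of the two numbers; compound 1 is its nearest neighbour and differs from it in two places at once, so the gap cannot be assigned to either change alone. Compound 3 `CCN(CC)c1nc(Nc2cccc([N+](=O)[O-])c2)nc(OCC(F)(F)C(F)F)n1` is not yet measured; relative to compound 2 it carries nitro in place of chloro on an aromatic carbon, and in this respect it matches compound 1. A downward step of moderate size from compound 2 to compound 3 is expected, a 3.6-fold lower number from compound 2 to compound 3 (0.56 log units; beyond the scatter), with wide uncertainty. Compound 3 is estimated at 1500 nM, within 350 nM to 6500 nM.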

Compound 3, half-maximal effective concentration: 1200 nM
The estimate for compound 3 lay 1.3-fold (0.10 log units) above the measured number, within the range that was stated.
By their numbers in this assay, from the lowest: compound 1; then compound 3; then compound 2.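

In this assay, the gap between compound 1 and compound 2 now splits into two single changes. With 2,2,3,3-tetrafluoropropyl held on the oxygen, 3-chlorophenyl to 3-nitrophenyl lowers the number (a 4.5-fold lower number from compound 2 to compound 3 (0.65 log units; beyond the scatter)). With 3-nitrophenyl held, 2,2,3,3-tetrafluoropropyl in place of 2,2,2-trifluoro-1-(trifluoromethyl)ethyl raises it (a 6.0-fold higher number from compound 1 to compound 3 (0.78 log units; beyond the scatter)), so both changes count, each beyond the scatter.

Going by these compounds, whether a nitrile or a carboxylic acid in place of the nitro group would continue this direction stays open. No available data bear on the reason for either step.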